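The source may report more compounds than this note shows. Statements on the series, on what has been measured and on what is new or still open speak of the compounds shown alone.

Measured so far:
compound 1, `COc1ccc2nc(C)cc(OC(C)(C)C(=O)Nc3cc(C)cc(C)c3)c2c1`: 20000 nM
compound 2, `COc1ccc2nc(C)cc(OCC(=O)Nc3cc(F)cc(F)c3)c2c1`: 13000 nM

Both compounds were tested in a physicochemical assay for solubility, in phosphate buffer, measured as kinetic solubility, with a stated time of 1 h, at pH 7.4; on this read-out lower numbers stand for lower solubility and higher numbers for higher solubility. Compound 1, `COc1ccc2nc(C)cc(OC(C)(C)C(=O)Nc3cc(C)cc(C)c3)c2c1`, gives 20000 nM. Compound 2, `COc1ccc2nc(C)cc(OCC(=O)Nc3cc(F)cc(F)c3)c2c1`, gives 13000 nM. Compound 2 has the lower of the two numbers, but its gap to compound 1 lies within the scatter, so the two values show no real difference between them. Among the compounds with values here, no step between two measured compounds that differ in one place is available to lean on.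

Compound 3, `COc1ccc2nc(C)cc(OCC(=O)Nc3cc(C)nc(C)n3)c2c1`, has not yet been measured. It differs from compound 2 in one place: 2,6-dimethylpyrimidin-4-yl in place of 3,5-difluorophenyl on an amide-type nitrogen. The amide-type nitrogen and the shared core stay as they are. Within the data shown here, with no measured step to guide it, the expectation rests on this one change alone. A modest rise in this assay from compound 2 to compound 3 is expected, of about a 2.3-fold higher number from compound 2 to compound 3 (0.36 log units; beyond the scatter), a step that may or may not clear the scatter. Compound 3 is therefore expected to give about 30000 nM, with a range from 10000 nM to 90000 nM.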

Compound 3, solubility: 5000 nM
Compound 3: the middle estimate sits 6.0-fold (0.78 log units) above what was measured; measured number outside the range, below it.
By their numbers in this assay, from the lowest: compound 3; then compounds 2 and 1 (each within the scatter of the next).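

On the amide-type nitrogen, the choice of aromatic ring does matter for this read-out: in this assay, putting 2,6-dimethylpyrimidin-4-yl in place of 3,5-difluorophenyl gives a 2.6-fold lower number from compound 2 to compound 3 (0.41 log units; beyond the scatter). The two groups have the same size, with 8 heavy atoms each and one six-membered aromatic ring, but the entering group has 2 hydrogen-bond acceptors where the leaving group has 0, so in this single pair the acceptors come with a lower number, not a higher one. Nothing measured here explains why the number falls.

The compounds shown do not separate the ring nitrogens from the methyl groups, and that question would need an unsubstituted pyrimidine ring or a pyridine ring on the same amide-type nitrogen. Also open, going by these compounds, is whether the same swap would give a similar step on the rest of compound 1, which differs from compound 2 in more than one place and so cannot be compared with compound 3 directly.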